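This account rests on a few compounds, and the source may have more. Where it says the series, first, only, none or still open, it means among the compounds named here.

Measured so far in an assay on cells for positive allosteric modulation of Cystic fibrosis transmembrane conductance regulator variant F508del (Homo sapiens), with stated times of 10 min and 7 s, in the presence of a further agent that is not named here; on this read-out higher numbers stand for an effect only at larger amounts of compound and lower numbers for an effect already at smaller amounts:
compound 1 `CC1Cc2c(sc(NC(=O)c3ccccc3O)c2C(N)=O)C(C)O1` gives 4 nM
compound 2 `CC1(C)Cc2c(sc(NC(=O)c3nnc[nH]3)c2C(N)=O)C(C)(C)O1` gives 467 nM
compound 3 `CC1(C)Cc2c(sc(NC(=O)c3cn[nH]c3)c2C(N)=O)C(C)(C)O1` gives 125 nM

Compound 3 stands second highest of the three numbers in this assay. Its nearest neighbour is compound 2, which sits higher; compound 1, on a different core and with a different acyl group, lies far lower. Among the compounds with values here, the one step within the gem-dimethyl core, a 3.7-fold lower number from compound 2 to compound 3 (0.57 log units; beyond the scatter), shows that exchanging one five-membered heteroaryl for another on the carbonyl carbon shifts the number modestly, beyond the scatter.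

Compound 4 `CC1(C)Cc2c(sc(NC(=O)C3(O)CC3)c2C(N)=O)C(C)(C)O1` carries the change (1-hydroxycyclopropyl in place of 1H-pyrazol-4-yl on a carbonyl carbon). Within the data shown here, no measured pair exchanges an aromatic ring for a saturated carbocycle at this position, so the only guide to the size of the move is a 3.7-fold lower number from compound 2 to compound 3 (0.57 log units; beyond the scatter). A shift of that order in either direction would not be surprising; a move toward a higher number is taken as somewhat more likely than a gain, but with wide uncertainty, since the donor and acceptor count is kept while the ring type changes.

Compound 4 is therefore estimated at 220 nM, within 50 nM to 900 nM. The expected step is a 1.8-fold higher number from compound 3 to compound 4 (0.25 log units; within the scatter).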

Compound 4, half-maximal effective concentration: 23 nM
Compound 4: the middle estimate sits 9.6-fold (0.98 log units) above what was measured; the measured number lies below the stated range.
By their numbers in this assay, from the lowest: compound 1; then compound 4; then compound 3; then compound 2.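

In this assay the position on the carbonyl carbon, whose other neighbour is the amide-type nitrogen, proves not to depend on an aromatic ring: 1-hydroxycyclopropyl in place of 1H-pyrazol-4-yl gives a 5.4-fold lower number from compound 3 to compound 4 (0.74 log units; beyond the scatter) and in place of 4H-1,2,4-triazol-3-yl gives a 20-fold lower number from compound 2 to compound 4 (1.31 log units; beyond the scatter) on the shared core. The earlier step showed only an exchange of one five-membered aromatic ring for another, whereas this change enters a three-membered non-aromatic ring of carbon only and leaves the counts of hydrogen-bond donors and acceptors as they were, so those counts alone do not fix the number at this position. Nothing available explains why the number falls with this change.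

On these data alone, it remains open whether the hydroxyl or the cyclopropane ring carries the step, which a plain cyclopropyl, a 1-aminocyclopropyl or an open-chain 2-hydroxypropan-2-yl group at the same place would separate. Also open, as far as these compounds go, is how the acyl group of compound 1 would read on the core of compound 4, since those two compounds differ in more than one place.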